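This account rests on a few compounds, and the source may have more. Where it says the series, first, only, none or still open, it means among the compounds named here.

Among the measured compounds shown here, in an ADME assay on microsomes from liver (Rattus norvegicus) for metabolic stability, read by LC-MS, with a stated time of 10 min, tested at 0.5 uM (a lower number here means that less of the compound is left, a higher number that more of the compound is left), compound 1 `CC(C)N1CCN(CCCN(C[C@H]2Cc3ccccc3CN2)[C@H]2CCCc3cccnc32)CC1` gives 4%, the lowest of the three numbers so far. Compound 4 `c1ccc2c(c1)CN[C@@H](CN(CCCCN1CCNCC1)[C@H]1CCCc3cccnc31)C2` is not yet measured. It differs from compound 1 by (piperazin-1-yl)methyl in place of 4-isopropylpiperazin-1-yl on a saturated chain carbon, three bonds along the chain from an amine nitrogen. For the measured compounds named here, no measured step covers this change. The only one, a number 30 percentage points lower from compound 2 to compound 3 (beyond the scatter), lies elsewhere in the structure and shows how far that other place can move the number. Compound 2 `c1cnc2c(c1)CCC[C@@H]2N(CCCN1CCNCC1)Cc1cc2ccccc2cn1` at 59% and compound 3 `c1cnc2c(c1)CCC[C@@H]2N(CCCN1CCNCC1)Cc1nc2ccccc2[nH]1` at 29% also carry piperazin-1-yl, which suggests a modest rise at most. The expected change is a number 14 percentage points higher from compound 1 to compound 4 (beyond the scatter). For compound 4 the estimate is 18%, with an expected range of 5% to 40%.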

Compound 4, percent of the compound remaining: 15%
Estimate against measurement, compound 4: 3 percentage points above; the measured number falls inside the stated range.
By their numbers in this assay, from the lowest: compound 1; then compound 4; then compound 3; then compound 2.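

In this assay, (piperazin-1-yl)methyl in place of 4-isopropylpiperazin-1-yl on a saturated chain carbon, three bonds along the chain from an amine nitrogen, gives a number 11 percentage points higher from compound 1 to compound 4 (beyond the scatter), so this end of the molecule also moves the number. The same difference reads as 2-(4-isopropylpiperazin-1-yl)ethyl to 3-(piperazin-1-yl)propyl, so the step joins loss of the isopropyl group with a longer chain and does not separate them. No supporting measurement bears on the reason for this rise.

As far as these compounds go, the separate contributions of the isopropyl group and the chain length remain open. So does the reading for a 4-methylpiperazin-1-yl group on either chain.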